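From 3,4-dichlorophenyl to ethyl in the series

The compounds below may be only part of what the source reports. "The series", "measured", "known", "first", "only" and "open" are said of these compounds alone.

In a functional assay on B16-F10 cells (Mus musculus) for antiproliferative activity, read by MTT assay, with a stated time of 48 h (a lower number here means a stronger inhibitor, a higher number a weaker inhibitor), compound 1 `Cc1ccc(N2CCN(C(=O)/C=C/c3ccc(O)c(O)c3)CC2)c(C)c1` gives 1.43 ug/mL and compound 2 `O=C(/C=C/c1ccc(O)c(O)c1)N1CCN(c2ccc(Cl)c(Cl)c2)CC1` gives 1.66 ug/mL so compound 2 stands level with compound 1 within the scatter. Going by the values given here, the only measured step is a 1.2-fold higher number from compound 1 to compound 2 (0.06 log units; within the scatter) and it exchanges one substituted phenyl group for another on the amine nitrogen. Compound 3 `CCN1CCN(C(=O)/C=C/c2ccc(O)c(O)c2)CC1` differs from compound 2 by ethyl in place of 3,4-dichlorophenyl on an amine nitrogen in a ring and here no phenyl group remains on that nitrogen. Among the compounds with values here, no measured compound carries such a change, so the step of a 1.2-fold higher number from compound 1 to compound 2 (0.06 log units; within the scatter) gives only weak guidance. A modest move toward a weaker number in this assay is expected, held with wide uncertainty. The expected size of the move is a 1.8-fold higher number from compound 2 to compound 3 (0.26 log units; within the scatter) on this estimate. For compound 3 the estimated value is 3 ug/mL with an expected range from 1.2 ug/mL to 12 ug/mL in this reading.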

Compound 3, half-maximal inhibitory concentration: 6.44 ug/mL
For compound 3 the middle estimate is 2.1-fold (0.33 log units) below the measured one, within the range that was stated.
By their numbers in this assay, from the lowest: compounds 1 and 2 (each within the scatter of the next); then compound 3.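

In this assay, the amine nitrogen in a ring now shows a step beyond the scatter: ethyl in place of 3,4-dichlorophenyl gives a 3.9-fold higher number from compound 2 to compound 3 (0.59 log units; beyond the scatter), and ethyl in place of 2,4-dimethylphenyl gives a 4.5-fold higher number from compound 1 to compound 3 (0.65 log units; beyond the scatter). The earlier step only exchanged one substituted phenyl group for another and stayed within the scatter, whereas these two changes remove the aromatic ring from this nitrogen and both move toward a weaker inhibitor. No measured property of these groups is available to explain the steps.

As far as these compounds go, whether an unsubstituted phenyl, a benzyl group or a longer chain such as hexyl on this nitrogen would stand with compound 2 or with compound 3 remains open. Also open, from the compounds shown here alone, is where a simple hydrogen on this nitrogen would fall relative to ethyl.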